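The compounds below may be only part of what the source reports. "The series", "measured", "known", "first", "only" and "open" are said of these compounds alone.

Measured compounds in a functional assay on HCT-116 cells (Homo sapiens) for cytotoxicity, with a stated time of 3 days; a lower number here means that less compound is needed, a higher number that more compound is needed for the effect:
Compound 1 `O=c1cc(-c2c[nH]c3ncccc23)nc(-c2ccccc2)[nH]1` gives 830 nM.
Compound 2 `O=c1cc(-c2c[nH]c3ncccc23)nc(Nc2ccccc2)[nH]1` gives 443 nM.
Compound 3 `O=c1cc(-c2c[nH]c3ncccc23)nc(NCc2ccccc2)[nH]1` gives 122 nM.

Compound 3 stands at the lowest number of the three: a 6.8-fold lower number from compound 1 to compound 3 (0.83 log units; beyond the scatter) and a 3.6-fold lower number from compound 2 to compound 3 (0.56 log units; beyond the scatter) are both beyond the scatter, whereas a 1.9-fold lower number from compound 1 to compound 2 (0.27 log units; within the scatter) is within it.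

Compound 4 `COC1CCN(c2nc(-c3c[nH]c4ncccc34)cc(=O)[nH]2)CC1` differs from compound 3 by 4-methoxypiperidin-1-yl in place of benzylamino on an aromatic carbon. Going by the values given here, no measured step covers this change. The two steps that reach compound 3 both end in the benzyl-bearing compound, and compound 4 has no benzyl group, so those steps give only an indirect hint that the number may rise again in this assay, by a modest amount, with considerable uncertainty in either direction.

Compound 4 is therefore expected to give about 400 nM, within 100 nM to 1500 nM. For compound 4 the expected step is a 3.3-fold higher number from compound 3 to compound 4 (0.52 log units; beyond the scatter).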

Compound 4, half-maximal effective concentration: 520 nM
Compound 4: middle estimate off by 1.3-fold (0.11 log units), on the low side; the measured number falls inside the stated range.
By their numbers in this assay, from the lowest: compound 3; then compounds 2, 4 and 1 (each within the scatter of the next).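

In this assay a non-aromatic ring at this position, with 4-methoxypiperidin-1-yl in place of benzylamino, gives a 4.3-fold higher number from compound 3 to compound 4 (0.63 log units; beyond the scatter). The same group in place of anilino gives a 1.2-fold higher number from compound 2 to compound 4 (0.07 log units; within the scatter) and in place of phenyl gives a 1.6-fold lower number from compound 1 to compound 4 (0.20 log units; within the scatter), so among these four compounds only the benzylamino compound stands apart. No measurement on hand accounts for this difference. From the compounds shown here alone, it remains open whether the methoxy group of compound 4 matters at all. Piperidin-1-yl, morpholin-4-yl or cyclohexylmethylamino at this position could show whether the benzene ring of benzylamino or its amine nitrogen goes with the low number of compound 3.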